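Acetyl to ethoxycarbonyl swap across two linker lengths

The source may hold more compounds than are shown below. What is called first, only, known or untested is meant among the compounds shown, and "the series" means these compounds.

In a functional assay on PC-12 cells (Rattus norvegicus) for cytotoxicity, read by MTT assay, with stated times of 3 h and 2 h, tested at 50 uM (on this read-out lower numbers stand for a weaker effect and higher numbers for a stronger effect at the one concentration tested), compound 1 `CC(=O)c1cc2ccc(OCCCn3cc(CNC(=O)CCCCC4CCSS4)nn3)cc2oc1=O` gives 40.7%. Compound 2 `CCOC(=O)c1cc2ccc(OCCCn3cc(CNC(=O)CCCCC4CCSS4)nn3)cc2oc1=O` carries ethoxy in place of methyl on a carbonyl carbon and gives 49.2% in this assay; the step is a number 8.5 percentage points higher from compound 1 to compound 2 (within the scatter). Compound 3 `CC(=O)c1cc2ccc(OCCCCCn3cc(CNC(=O)CCCCC4CCSS4)nn3)cc2oc1=O` gives 18.2% in this assay, the lowest of the three numbers; the difference between the core of compound 3 and the core of compound 1 is not broken down here. Within the data shown here, compound 4 `CCOC(=O)c1cc2ccc(OCCCCCn3cc(CNC(=O)CCCCC4CCSS4)nn3)cc2oc1=O` has not yet been measured in this assay; it differs from compound 3 by ethoxy in place of methyl on a carbonyl carbon, the same change, on the same place, as the one from compound 1 to compound 2. Among the measured compounds shown here, the expected step of a number 7.8 percentage points higher from compound 3 to compound 4 (within the scatter) rests on the single earlier step of a number 8.5 percentage points higher from compound 1 to compound 2 (within the scatter), which stayed within the scatter. Compound 4 is estimated at 26% in this assay, expected to fall between 12% and 42%.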

Compound 4, a percentage reported as activity, at one concentration (the size of the read-out at that concentration, not a potency): 40.7%
Estimate against measurement, compound 4: 14.7 percentage points below, within the range that was stated.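

In this assay, ethoxy in place of methyl on a carbonyl carbon gives a number 22.5 percentage points higher from compound 3 to compound 4 (beyond the scatter). Set beside the earlier step, this result gives no ground for calling the size of the change different on the two cores: the same change on two cores in this assay, a number 8.5 percentage points higher (within the scatter) from compound 1 to compound 2 and a number 22.5 percentage points higher (beyond the scatter) from compound 3 to compound 4, 14 percentage points apart, within the scatter of two such steps The change therefore carries over as far as these two pairs can tell, but only one step lies beyond the scatter, so two cores fix neither a shared step size nor a rule for other cores in the series.

Still open, on these data alone, is whether the step holds with a carboxylic acid or an isopropoxy group on the carbonyl carbon. Also open, as far as these compounds go, is how it behaves on a core with a longer chain than that of compound 3.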